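Aryl substituent change from compound 3 to compound 4

The compounds below may be only part of what the source reports. "The series", "measured", "known", "first", "only" and "open" are said of these compounds alone.

Compound 3 `C[C@@H](NC(=O)Nc1ccc(C(F)(F)F)cc1)c1ccccc1` gives 93% in an ADME assay on the whole organism with Oryza sativa as the target, tested at 0.1 uM (on this read-out lower numbers stand for a stronger effect and higher numbers for a weaker effect at the one concentration tested), the second highest of the three numbers in hand. Compound 1 `Cc1ccc(NC(=O)N[C@H](C)c2ccccc2)cc1` gives 100% in this assay. The step of a number 7 percentage points lower from compound 1 to compound 3 (within the scatter). Compound 2 `CCCc1ccc(NC(=O)N[C@H](C)c2ccccc2)cc1` gives 33% in this assay. The step of a number 60 percentage points higher from compound 2 to compound 3 (beyond the scatter); likewise a number 67 percentage points lower from compound 1 to compound 2 (beyond the scatter). Compound 4 `CC(=O)c1ccc(NC(=O)N[C@H](C)c2ccccc2)cc1` carries the change (acetyl in place of trifluoromethyl on an aromatic carbon). Both steps at this aromatic carbon bear on it: methyl and trifluoromethyl sit together within the scatter, while propyl sits far lower. Acetyl, with its three heavy atoms, is closer in size to those two than to propyl, so the expected step is a number 8 percentage points lower from compound 3 to compound 4 (within the scatter), with room for a drop. Compound 4 is estimated at 85%, between 55% and 100%.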

Compound 4, a percentage reported as activity, at one concentration (the size of the read-out at that concentration, not a potency): 96%
Estimate against measurement, compound 4: 11 percentage points below; the measured number falls inside the stated range.
By their numbers in this assay, from the lowest: compound 2; then compounds 3, 4 and 1 (each within the scatter of the next).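

In this assay acetyl, with its hydrogen-bond acceptor and its double bond outside aromatic rings, reads level with trifluoromethyl (a number 3 percentage points higher from compound 3 to compound 4 (within the scatter)) and with methyl (a number 4 percentage points lower from compound 1 to compound 4 (within the scatter)). Against propyl the step stays large (a number 63 percentage points higher from compound 2 to compound 4 (beyond the scatter)), so of the four groups at this aromatic carbon only propyl, in compound 2, stands apart. Nothing measured here accounts for that gap. As far as these compounds go, whether ethyl already gives the low read-out of propyl, or a longer chain such as butyl goes lower still, remains open. An amine or a carboxylic acid at this carbon also remains an open case.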